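The source may hold more compounds than are shown below. What is called first, only, known or untested is meant among the compounds shown, and "the series" means these compounds.

Working notes on the series. a functional assay on the whole organism for inhibition, with Rattus norvegicus as the target, read by paw edema, with stated times of 1 h and 3 h, at a dose of 100 mg/kg by the oral route (on this read-out higher numbers stand for more inhibition at the one dose given (going by the name of the read-out) and lower numbers for less inhibition), has so far been run on three compounds. Compound 1, `O=C(O)c1ccc(NC(=O)[C@@H]2CC(O)CN2S(=O)(=O)c2ccc([N+](=O)[O-])cc2)cc1`, gives 62.8%. Compound 2, `Cc1ccccc1S(=O)(=O)N1CCC[C@H]1C(=O)Nc1ccc(C(=O)O)cc1`, gives 40.1%. Compound 3, `Cc1ccc(S(=O)(=O)N2CCC[C@H]2C(=O)Nc2ccc(C(=O)O)cc2)cc1`, gives 35.3%. For the measured compounds named here, the one single-point step measured, a number 4.8 percentage points lower from compound 2 to compound 3 (within the scatter), moves the methyl around the ring and stays within the scatter; compound 3 and compound 2 are therefore not told apart by this assay. Compound 1 stands beyond the scatter above compound 3.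

Compound 4, `O=C(O)c1ccc(NC(=O)[C@@H]2CCCN2S(=O)(=O)c2ccc([N+](=O)[O-])cc2)cc1`, is not yet measured. It differs from compound 3 in one place: nitro in place of methyl on an aromatic carbon. Going by the values given here, no measured step matches this change. The step from compound 2 to compound 3 concerns only where the methyl sits and says nothing about a nitro entering. Compound 1 does carry the same 4-nitrophenyl on the sulfonyl sulfur, but it differs from compound 4 in a second place as well, so its value alone cannot be read as the effect of the nitro.

With that, compound 4 is expected to lie between compound 3 and compound 1, a step of a number 12.7 percentage points higher from compound 3 to compound 4 (beyond the scatter) in this assay, with low confidence. Compound 4 is estimated at 48%, within a range of 30% to 68%.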

Compound 4, a percentage reported as inhibition, in the whole organism at one dose (the size of the read-out at that dose, not a potency): 52.3%
Beside the measured number, compound 4's estimate is 4.3 percentage points below it; the range from low to high includes it.
By their numbers in this assay, from the lowest: compounds 3 and 2 (each within the scatter of the next); then compound 4; then compound 1.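

In this assay, for the compounds shown here, the 4-nitrophenyl on the sulfonyl sulfur gives the first change at this position that clears the scatter: a number 17 percentage points higher from compound 3 to compound 4 (beyond the scatter) for nitro in place of methyl on an aromatic carbon, and a number 12.2 percentage points higher from compound 2 to compound 4 (beyond the scatter) for the full exchange of 2-methylphenyl, whereas moving the methyl alone left compound 2 and compound 3 untold apart. The series also now has a one-place reading of the hydroxy on the saturated ring carbon with the 4-nitrophenyl held fixed, a number 10.5 percentage points lower from compound 1 to compound 4 (beyond the scatter), so the nitro does not account for the whole of the number of compound 1. Nothing on hand bears on why either change moves the read-out, and these steps stand as observations only.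

From the compounds shown here alone, whether an amine or a chlorine on the same aromatic carbon would read with the nitro or with the methyl stays open, so two groups at this place give no trend. Also open, going by these compounds, is whether the hydroxy step holds with 4-methylphenyl on the sulfonyl sulfur, and whether a methoxy in place of that hydroxy would keep it.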